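Extending an Ester Chain by One Carbon

The source may hold more compounds than are shown below. What is called first, only, known or untested is meant among the compounds shown, and "the series" means these compounds.

Of the compounds shown here, three built on a shared core have been measured in a functional assay on A549 cells (Homo sapiens) for cytotoxicity, read by MTT assay, with a stated time of 24 h, tested at 60 uM; a higher number here means a weaker effect of the compound at the concentration tested, a lower number a stronger effect. Compound 1 `CCCCCOC(=O)CCC(=O)N1CCN(CCCOc2cc3c(Nc4ccc(F)c(Cl)c4)ncnc3cc2OC)CC1` gives 30%. Compound 2 `CCCCCCCCCCCCCOC(=O)CCC(=O)N1CCN(CCCOc2cc3c(Nc4ccc(F)c(Cl)c4)ncnc3cc2OC)CC1` gives 20.6%, and compound 3 `CCCCCCCCCCCCCCOC(=O)CCC(=O)N1CCN(CCCOc2cc3c(Nc4ccc(F)c(Cl)c4)ncnc3cc2OC)CC1` gives 84.9%. Among these three, compound 3 stands highest: the step of a number 54.9 percentage points higher from compound 1 to compound 3 (beyond the scatter) and the step of a number 64.3 percentage points higher from compound 2 to compound 3 (beyond the scatter) both lie beyond the scatter, whereas the step of a number 9.4 percentage points lower from compound 1 to compound 2 (within the scatter) does not. Compound 4 `CCCCCCCCCCCCCCCOC(=O)CCC(=O)N1CCN(CCCOc2cc3c(Nc4ccc(F)c(Cl)c4)ncnc3cc2OC)CC1` is the next member of this series and has not yet been measured. It differs from compound 3 by methyl in place of hydrogen on a saturated chain carbon, ten or more bonds along the chain from an oxygen next to a carbonyl group. The measured step that bears most directly on this change is a number 64.3 percentage points higher from compound 2 to compound 3 (beyond the scatter), the same kind of change made one carbon earlier, and it was large. Yet a number 9.4 percentage points lower from compound 1 to compound 2 (within the scatter) shows that a much longer extension of the same chain left the number within the scatter, so the series does not move steadily with chain length. Within the data shown here, because compound 3 already sits at 84.9%, a further upward step of the earlier size has little room, and the single precedent gives no firm direction. Compound 4 is therefore expected to give 75%, within 35% to 100%, which amounts to an expected step of a number 9.9 percentage points lower from compound 3 to compound 4 (within the scatter).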

Compound 4, a percentage reported as activity, at one concentration (the size of the read-out at that concentration, not a potency): 81.6%
Beside the measured number, compound 4's estimate is 6.6 percentage points below it, and the stated range covers the measured number.
By their numbers in this assay, from the lowest: compounds 2 and 1 (each within the scatter of the next); then compounds 4 and 3 (each within the scatter of the next).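

In this assay, methyl in place of hydrogen on a saturated chain carbon now gives a small step (a number 3.3 percentage points lower from compound 3 to compound 4 (within the scatter)), although the same change one carbon earlier gave a large one (a number 64.3 percentage points higher from compound 2 to compound 3 (beyond the scatter)). Among these compounds, the high number is thus shared by two neighbouring chain lengths rather than resting on compound 3 alone: compound 4 also stands well clear of the two other compounds (a number 61 percentage points higher from compound 2 to compound 4 (beyond the scatter); a number 51.6 percentage points higher from compound 1 to compound 4 (beyond the scatter)), so these four compounds fall into a low pair and a high pair, with the sharp change lying in the single step to compound 3. Nothing available here bears on why the number changes so sharply at that step and then holds.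

Open, on these data alone, is whether a still longer chain would stay with compound 3 and compound 4 or move away from them, and where the change falls among chains intermediate in length between those of compound 1 and compound 2. Also open, as far as these compounds go, is how a chain ending in an amine or a carboxylic acid would behave at this place.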